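A few compounds are considered here, and "the series" means these few. Any claim that something is new, unique, unknown or untested is made for them only; others in the source may bear on it.

Going by the values given here, compound 1 `CNC(=O)c1cc(Oc2ccc(C(=O)/C=C/c3ccc(F)cc3Cl)cc2)ccn1` is the only member of this set with a number. In a functional assay on A549 cells (Homo sapiens) for cytotoxicity, read by MTT assay, with a stated time of 72 h (a lower number here means a stronger inhibitor, a higher number a weaker inhibitor), compound 1 gives 21100 nM. Its companions compound 2 `CNC(=O)c1cc(Oc2ccc(C(=O)/C=C/c3ccco3)cc2)ccn1` and compound 3 `CNC(=O)c1cc(Oc2ccc(C(=O)/C=C/c3ccc(OC)c(OC)c3OC)cc2)ccn1`, which carry a furan-bearing and a trimethoxyphenyl-bearing chain on the same core, have no result in this assay: compound 2 gives "not determined" (no result reported), and compound 3 gives "not determined" (no result reported), so compound 1 cannot be placed higher or lower than either of them. Compound 4 `CNC(=O)c1cc(Oc2ccc(C(=O)/C=C/c3cccc(Cl)c3Cl)cc2)ccn1` differs from compound 1 in one place (2,3-dichlorophenyl in place of 2-chloro-4-fluorophenyl on a double-bonded chain carbon bound to a double-bonded chain carbon). Among the compounds with values here, with no measured step to lean on, the change from compound 1 to compound 4 is expected to stay within the scatter of this assay, with at most a slight gain in potency. The step expected from compound 1 to compound 4 is a 1.4-fold lower number from compound 1 to compound 4 (0.15 log units; within the scatter). For compound 4 the estimate in this assay is 15000 nM, with a range from 5000 nM to 50000 nM.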

Compound 4, half-maximal inhibitory concentration: > 50000 nM
Compound 4 ended at the assay's limit; the forecaster's own chance of this, stated with the estimate: 10%; at least 3.3-fold (0.52 log units) between middle value and limit.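

In this assay, 2,3-dichlorophenyl in place of 2-chloro-4-fluorophenyl on a double-bonded chain carbon bound to a double-bonded chain carbon gives an at least 2.3-fold higher number from compound 1 to compound 4 (0.37 log units; beyond the scatter), so this position does respond to a change between two chlorine-bearing phenyl groups. Compound 4 stands at a limit of the assay and not at a number, so the step has a lower bound only: the limit of > 50000 nM in this assay, at which 1 of the 4 values shown sits.

Steps to compound 2 and compound 3 cannot be read. Going by these compounds, whether an amine or a carboxylic acid on the phenyl group at this position would give a lower number remains open.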